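The source may hold more compounds than are shown below. What is called first, only, known or untested is meant among the compounds shown, and "the series" means these compounds.

The series shares one core, and the substituent on that core is what varies. Compound 1 `CCCCSC1=CC(=O)C(C[C@]2(C)[C@@H](C)CC[C@]3(C)C(C)=CCC[C@@H]23)=CC1=O` and compound 3 `CCCSC1=CC(=O)C(C[C@]2(C)[C@@H](C)CC[C@]3(C)C(C)=CCC[C@@H]23)=CC1=O` carry a butylsulfanyl and a propylsulfanyl group, but neither has a number in an ADME assay on PBMC cells (Homo sapiens) for cytotoxicity, read by MTT assay; a lower number here means a stronger inhibitor, a higher number a weaker inhibitor: compound 1 gives "not determined" (no result reported) and compound 3 gives "not determined" (no result reported), so compound 3 stands without a measured point of its own. For the measured compounds named here, the only number in this assay comes from compound 2 `COC1=CC(=O)C=C(C[C@]2(C)[C@@H](C)CC[C@]3(C)C(C)=CCC[C@@H]23)C1=O`, which gives 5900 nM. Compound 4 `CC1=CCC[C@H]2[C@](C)(CC3=CC(=O)C(Sc4ccccc4)=CC3=O)[C@@H](C)CC[C@]12C` differs from compound 3 by phenyl in place of propyl on a sulfur. Going by the values given here, no step between measured compounds exists to calibrate this change, so an expectation can rest only on the single value of compound 2. Compound 4 is therefore estimated at 5000 nM, with a range from 1500 nM to 20000 nM.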

Compound 4, half-maximal inhibitory concentration: 9900 nM
The estimate for compound 4 lay 2.0-fold (0.30 log units) below the measured number; the measured number falls inside the stated range.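

No step can be read between compound 3 and compound 4 in this assay, as compound 3 holds no single number there. What the change from propylsulfanyl to phenylsulfanyl does to this read-out stays open, and no further data shown here bear on it.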